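Swapping Methyl for Nitro on the Ketone-Side Ring

This account rests on a few compounds, and the source may have more. Where it says the series, first, only, none or still open, it means among the compounds named here.

Of the compounds shown here, two that share one core have been measured for binding to a nucleic acid. In an assay on nucleic acid for binding affinity to Calf thymus DNA (Bos taurus) (on this read-out higher numbers stand for weaker inhibition and lower numbers for stronger inhibition), compound 1 `O=C(/C=C/c1cc2ccccc2nc1Cl)c1ccccc1` gives 572 nM, and compound 2 `Cc1ccc(C(=O)/C=C/c2cc3ccccc3nc2Cl)cc1` gives 540 nM. For the measured compounds named here, the single step between them, a 1.1-fold lower number from compound 1 to compound 2 (0.03 log units; within the scatter), means the two numbers cannot be told apart, so compound 2 stands side by side with compound 1 rather than apart from it.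

Compound 3 `O=C(/C=C/c1cc2ccccc2nc1Cl)c1ccc([N+](=O)[O-])cc1` has not been measured yet. It differs from compound 2 by nitro in place of methyl on an aromatic carbon. Going by the values given here, no measured pair exchanges a methyl for a nitro, so the only step that bears on this aromatic carbon is the one from hydrogen to methyl, a 1.1-fold lower number from compound 1 to compound 2 (0.03 log units; within the scatter), which stayed within the scatter. That step gives no sign that this carbon governs binding, so the expectation is a small change at most, in no preferred direction. The expected step is a 1.0-fold lower number from compound 2 to compound 3 (0.02 log units; within the scatter). Among the compounds with values here, for compound 3 the estimate in this assay is 520 nM, within a range from 200 nM to 1400 nM, the width reflecting that no measured compound carries a nitro.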

Compound 3, inhibition constant: 531 nM
Compound 3: the middle estimate sits 1.0-fold (0.01 log units) below what was measured, within the range that was stated.
By their numbers in this assay, from the lowest: compounds 3, 2 and 1 (each within the scatter of the next).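

At this aromatic carbon, para to a large group, this assay now gives a 1.0-fold lower number from compound 2 to compound 3 (0.01 log units; within the scatter) and a 1.1-fold lower number from compound 1 to compound 3 (0.03 log units; within the scatter), so compounds carrying hydrogen, methyl and nitro here cannot be told apart. The earlier pair compared only hydrogen with methyl, a single added heavy atom, whereas nitro brings 3 heavy atoms and 2 hydrogen-bond acceptors in place of the 1 heavy atom and 0 acceptors of methyl, and the read-out still does not separate the compounds. The three compounds therefore show that this position tolerates a wider swap than the first step alone could show, although no measurement shown here explains why the numbers stay together.

From the compounds shown here alone, it remains open whether this tolerance would hold for an amine, a carboxylic acid or a longer chain at the same carbon, since all three groups seen so far have 0 hydrogen-bond donors and no net charge. Going by these compounds, it is also open whether changes elsewhere would matter more, such as replacing the chlorine on the shared core or moving a group to another carbon of this ring.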